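The source may report more compounds than this note shows. Statements on the series, on what has been measured and on what is new or still open speak of the compounds shown alone.

Compound 1 `C/C(=C\c1cc(-c2ccc(C)cc2)cs1)C(N)=O`: > 50000 nM
Compound 2 `C/C(=C\c1cc(-c2ccc(S(C)(=O)=O)cc2)cs1)C(N)=O`: > 50000 nM

In a functional assay on T-24 cells (Homo sapiens) for cytotoxicity, read by CCK-8 assay, with a stated time of 24 h (a higher number here means a weaker inhibitor, a lower number a stronger inhibitor), compound 2 stands at a limit of the assay, not at a number; it shares the limit of > 50000 nM in this assay, at which 2 of the 2 values shown sit, with compound 1. Compound 3 `C/C(=C\c1cc(-c2ccc(C(F)(F)F)cc2)cs1)C(N)=O` differs from compound 2 by trifluoromethyl in place of methylsulfonyl on an aromatic carbon. Within the data shown here, the one measured step that touches this position, a step that the two limits leave unreadable from compound 1 to compound 2, is unreadable, so no size or direction can be drawn from it. Compound 3 is therefore expected to remain near the same limit, estimated at 60000 nM with a range from 20000 nM to 200000 nM. The expected step from compound 2 to compound 3 is a step that the limit leaves unreadable from compound 2 to compound 3.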

Compound 3, half-maximal inhibitory concentration: > 50000 nM
Compound 3 was reported as a limit; the forecaster's own chance of this, stated with the estimate: 85%; the middle value lies beyond the limit too.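

No step can be read among compound 1, compound 2 and compound 3, since all three stand at a limit and not at a number: the limit of > 50000 nM in this assay, at which 3 of the 3 values shown sit.

The compounds shown leave open how far beyond that limit each one lies, and whether another group in this place would give a readable value.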